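From 4-chlorophenyl to 3-fluorophenyl at the benzylic position

This account rests on a few compounds, and the source may have more. Where it says the series, first, only, none or still open, it means among the compounds named here.

Going by the values given here, compound 2 `NC(N)=NC(=O)c1nc(Cl)c(NCc2ccc(Cl)cc2)nc1N` stands highest of the two compounds measured so far in an assay for inhibition of acid-sensing ion channel 3 (Homo sapiens), read by patch clamp, tested at 1 uM (a higher number here means more inhibition at the concentration tested (going by the name of the read-out), a lower number less inhibition), giving 46%. Its neighbour compound 1 `C=CCNc1nc(N)c(C(=O)N=C(N)N)nc1Cl` gives 16%, and the step of a number 30 percentage points higher from compound 1 to compound 2 (beyond the scatter) is the only one recorded. Compound 3 `NC(N)=NC(=O)c1nc(Cl)c(NCc2cccc(F)c2)nc1N` differs from compound 2 by 3-fluorophenyl in place of 4-chlorophenyl on a saturated chain carbon bound to a nitrogen on an aromatic ring. Among the compounds with values here, no measured step exchanges one substituted phenyl for another, so the recorded step offers only indirect guidance. Compound 3 is therefore expected to sit near compound 2, with a step of a number 8 percentage points lower from compound 2 to compound 3 (within the scatter) that may not exceed the scatter. The estimate for compound 3 is 38%, ranging from 20% to 55%.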

Compound 3, a percentage reported as inhibition, at one concentration (the size of the read-out at that concentration, not a potency): 29%
Compound 3: the middle estimate sits 9 percentage points above what was measured; the range from low to high includes it.
By their numbers in this assay, from the lowest: compound 1; then compound 3; then compound 2.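

In this assay, going by these compounds alone, changing only the substituted phenyl at this position gives a measurable shift, with a number 17 percentage points lower from compound 2 to compound 3 (beyond the scatter), the only step here between two substituted phenyl groups. The 3-fluorophenyl group still stands ahead of vinyl on the same saturated chain carbon, with a number 13 percentage points higher from compound 1 to compound 3 (beyond the scatter), so both substituted phenyl compounds exceed the vinyl compound, though not equally. No evidence is available that bears on why the two phenyl groups differ.

The compounds shown leave open whether the identity of the halogen or its place on the phenyl ring accounts for the step, which 4-fluorophenyl or 3-chlorophenyl could separate. Going by these compounds, how an unsubstituted phenyl or a longer chain would compare also remains open.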